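Fluoro to nitro on compound 1

The compounds below may be only part of what the source reports. "The series", "measured", "known", "first", "only" and "open" are said of these compounds alone.

Within the data shown here, in a physicochemical assay for solubility, at pH 7.4 (on this read-out lower numbers stand for lower solubility and higher numbers for higher solubility), compound 1 (`NS(=O)(=O)c1ccc(SCCO)c(F)c1`) gives 6000 ug/mL and holds the higher of the two numbers so far, while compound 2 (`NS(=O)(=O)c1ccc(SCCCO)c(F)c1`) gives 900 ug/mL as the only comparison. Compound 3 (`NS(=O)(=O)c1ccc(SCCO)c([N+](=O)[O-])c1`) departs from compound 1 at a different place: nitro in place of fluoro on an aromatic carbon that is, nitro in place of fluoro on an aromatic carbon. Among the measured compounds shown here, no measured step covers this aromatic carbon. For the measured compounds named here, the only measured step, a 6.7-fold lower number from compound 1 to compound 2 (0.82 log units; beyond the scatter) is hydroxymethyl in place of hydroxy on a saturated chain carbon, so it serves only as a rough gauge of size. With compound 1 at 6000 ug/mL at the top of the range, a modest fall is expected in this assay rather than a rise, and the expected step is a 4.0-fold lower number from compound 1 to compound 3 (0.60 log units; beyond the scatter) with wide uncertainty. Compound 3 is estimated at 1500 ug/mL (expected range 400 ug/mL to 5000 ug/mL).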

Compound 3, solubility: 500 ug/mL
Compound 3: the middle estimate sits 3.0-fold (0.48 log units) above what was measured; the measured number falls inside the stated range.
By their numbers in this assay, from the lowest: compounds 3 and 2 (each within the scatter of the next); then compound 1.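

Among these compounds, the aromatic carbon ortho to a (2-hydroxyethyl)sulfanyl group and meta to a sulfamoyl group is the first place outside the chain seen to move the read-out in this assay, with a 12-fold lower number from compound 1 to compound 3 (1.08 log units; beyond the scatter). The read-out therefore responds to a change on this aromatic carbon as well as to one on the chain, here with fluoro (1 heavy atom) giving way to nitro (3 heavy atoms), neither carrying a net charge. No supporting measurement bears on why this change lowers the number.

Only one replacement for fluoro at this carbon is shown, so how an amine, a nitrile or a carboxylic acid would read there stays open. Also open, from the compounds shown here alone, is whether nitro in place of fluoro on the core of compound 2 gives a step of similar size.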